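Double-bond geometry on the shorter chain: compound 4

A few compounds are considered here, and "the series" means these few. Any claim that something is new, unique, unknown or untested is made for them only; others in the source may bear on it.

Compound 1 `CCCCCCCCCCCC/C=C\N(NC(=O)COC)C(=O)OC(C)(C)C`: in a functional assay on HeLa cells (Homo sapiens) for cytotoxicity, with a stated time of 72 h (on this read-out lower numbers stand for higher toxicity in this test and higher numbers for lower toxicity in this test), compound 1 gives 85300 nM.
Compound 2 `CCCCCCCCCCCC/C=C/N(NC(=O)COC)C(=O)OC(C)(C)C`: compound 2 gives 57700 nM.
Compound 3 `CCCCCCCC/C=C/N(NC(=O)COC)C(=O)OC(C)(C)C`: compound 3 gives 83200 nM.

Among these three numbers, compound 3 stands second highest. Its nearest neighbour is compound 1 and its furthest compound 2, and both gaps are within the scatter, so the three measured compounds cannot be told apart on this read-out.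

Compound 4 `CCCCCCCC/C=C\N(NC(=O)COC)C(=O)OC(C)(C)C` differs from compound 3 in one respect: the two compounds have the same atoms and bonds and differ only in configuration as drawn: 1 of 1 stereo elements differ; a double bond is drawn E in compound 3 and Z in compound 4. For the measured compounds named here, one measured step bears directly on this change, the one in which the fact that compounds 1 and 2 differ only in the configuration as drawn: a 1.5-fold lower number from compound 1 to compound 2 (0.17 log units; within the scatter). That step ran from Z to E, the reverse of the direction taken from compound 3 to compound 4, and it stayed within the scatter. The other step, a 1.4-fold higher number from compound 2 to compound 3 (0.16 log units; within the scatter), concerns the chain length rather than the geometry and was likewise within the scatter.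

On this basis no step beyond the scatter is expected for compound 4, with at most a slight lean toward a higher number, mirroring the step from compound 1 to compound 2. Compound 4 is therefore estimated at 105000 nM, with a range from 50000 nM to 220000 nM. The expected step is a 1.3-fold higher number from compound 3 to compound 4 (0.10 log units; within the scatter).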

Compound 4, half-maximal cytotoxic concentration: 105000 nM
Compound 4: middle estimate and measured number agree at the digits printed, within the range that was stated.
By their numbers in this assay, from the lowest: compounds 2, 3, 1 and 4 (each within the scatter of the next).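

In this assay, turning the double bond from E to Z on the shorter chain gives a 1.3-fold higher number from compound 3 to compound 4 (0.10 log units; within the scatter), so the geometry has now been read on two chain lengths, and on neither does it move the number beyond the scatter. The chain change, hydrogen in place of butyl on a saturated chain carbon, could previously be read only between the E compounds, and between the Z compounds it gives a 1.2-fold higher number from compound 1 to compound 4 (0.09 log units; within the scatter). The two readings of this change therefore agree, whichever geometry the double bond has: the same change on two cores in this assay, a 1.4-fold higher number (0.16 log units; within the scatter) from compound 2 to compound 3 and a 1.2-fold higher number (0.09 log units; within the scatter) from compound 1 to compound 4, 1.2-fold (0.07 log units) apart, within the scatter of two such steps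

The four compounds differ only in chain length and double-bond geometry, and each stands within the scatter of the next, so they do not show whether any change to this series can move the number beyond the scatter. Still open, as far as these compounds go, is what a much shorter chain, a fully saturated chain, or an amine or a carboxylic acid carried on the chain would do in this assay.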